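The compounds below may be only part of what the source reports. "The series", "measured", "known", "first", "only" and "open" are said of these compounds alone.

The three measured compounds in a functional assay on ACHN cells (Homo sapiens) for cytotoxicity, read by sulforhodamine B assay, with a stated time of 48 h; a higher number here means a weaker inhibitor of growth, a lower number a stronger inhibitor of growth:

Compound 1 `ClCc1ccc(Cn2cnc3c(Cl)ncnc32)cc1` gives 1280 nM.
Compound 2 `ClCc1cccc(Cn2cnc3ncnc(Cl)c32)c1` gives 3540 nM.
Compound 3 `ClCc1ccccc1Cn1cnc2ncnc(Cl)c21` gives 4260 nM.

Compound 3 stands at the highest of the three numbers. Compound 2 sits within the scatter of it, so the two cannot be told apart on this evidence. Compound 1 gives a lower number than compound 3, and that difference lies beyond the scatter, so compound 1 is the stronger inhibitor of growth of the pair.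

Compound 4 `ClCc1ccccc1Cn1cnc2nc(Cl)nc(Cl)c21` is drawn from compound 3 by one change: chloro in place of hydrogen on an aromatic carbon. Among the compounds with values here, no measured pair here shows this same change, so nothing in these numbers tells which way it will move the read-out. The expected step from compound 3 to compound 4 in this assay is therefore small, a 1.4-fold lower number from compound 3 to compound 4 (0.15 log units; within the scatter), with a wide range in either direction. On that basis compound 4 is estimated at 3000 nM, expected to fall between 900 nM and 10000 nM.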

Compound 4, concentration for total growth inhibition: 1250 nM
Estimate against measurement, compound 4: 2.4-fold (0.38 log units) above, and the stated range covers the measured number.
By their numbers in this assay, from the lowest: compounds 4 and 1 (each within the scatter of the next); then compounds 2 and 3 (each within the scatter of the next).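

In this assay, chloro in place of hydrogen on the aromatic carbon between two ring nitrogen atoms gives a 3.4-fold lower number from compound 3 to compound 4 (0.53 log units; beyond the scatter) and this modest step lies beyond the scatter. It is the first change in one place among these compounds, and it shows that the read-out responds to what sits at this carbon, with the stronger inhibition of growth lying on the chloro side of the pair. Nothing measured here gives a reason for the step.

Whether an amine, a methoxy group or a fluoro group on this same carbon would move the read-out in the same direction stays open, since only chloro is shown there. As far as these compounds go, it is also open whether chloro at this carbon would give a like step on compound 1 or compound 2, which both carry hydrogen there.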